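Series notes: the step from compound 3 to compound 4

The source may report more compounds than this note shows. Statements on the series, on what has been measured and on what is new or still open speak of the compounds shown alone.

Readings in a functional assay on SH-SY5Y cells (Homo sapiens) for cytotoxicity, read by MTT assay, with a stated time of 48 h, tested at 1 uM (on this read-out higher numbers stand for a weaker effect at the one concentration tested and lower numbers for a stronger effect), for the three compounds measured so far:
compound 1 `O=C(CCCCCCCc1cn(-c2ccccc2-c2ccccc2)nn1)Nc1ccncc1` gives 82%
compound 2 `O=C(CCc1cccnc1)NCCCCCc1cn(-c2ccccc2-c2ccccc2)nn1` gives 54%
compound 3 `O=C(CCCCCc1cn(-c2ccccc2-c2ccccc2)nn1)NCc1cccnc1` gives 13.4%

Compound 3 stands lowest of the three, the strongest effect at the single concentration tested; its nearest neighbour on the numbers is compound 2, and compound 1 lies furthest off. The steps among the measured compounds are a number 28 percentage points lower from compound 1 to compound 2 (beyond the scatter), a number 68.6 percentage points lower from compound 1 to compound 3 (beyond the scatter) and a number 40.6 percentage points lower from compound 2 to compound 3 (beyond the scatter).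

Compound 4 `O=C(/C=C/c1cccnc1)NCCCCCc1cn(-c2ccccc2-c2ccccc2)nn1` has not been measured. Relative to compound 3 the change is ((2-(pyridin-3-yl)ethenyl)carbonyl)amino in place of ((pyridin-3-yl)methyl)carbamoyl on a saturated chain carbon, five bonds along the chain from an aromatic carbon. Among the measured compounds shown here, the one measured step that bears on it is a number 40.6 percentage points lower from compound 2 to compound 3 (beyond the scatter): compound 2 carries the ((2-(pyridin-3-yl)ethyl)carbonyl)amino group, which differs from what enters in compound 4 only by one double bond outside aromatic rings. Compound 4 is therefore expected to move back toward the number of compound 2, an expected step of a number 36.6 percentage points higher from compound 3 to compound 4 (beyond the scatter), beyond the scatter and in the direction of a weaker effect. For the measured compounds named here, no measured pair shows how much the added double bond on its own shifts the number, so the range is kept wide. Compound 4 is estimated at 50%, with a range from 25% to 78%.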

Compound 4, a percentage reported as activity, at one concentration (the size of the read-out at that concentration, not a potency): 32%
Estimate against measurement, compound 4: 18 percentage points above, and the stated range covers the measured number.
By their numbers in this assay, from the lowest: compound 3; then compound 4; then compound 2; then compound 1.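

Among the compounds shown here, replacing 2-(pyridin-3-yl)ethyl with 2-(pyridin-3-yl)ethenyl on a carbonyl carbon gives a number 22 percentage points lower from compound 2 to compound 4 (beyond the scatter) in this assay, the first measured pair to isolate the double bond, and it shows that this one change outside the aromatic ring moves the number beyond the scatter, towards a stronger effect. The double bond does not close the whole gap to the ((pyridin-3-yl)methyl)carbamoyl group, since the change at this saturated chain carbon still gives a number 18.6 percentage points higher from compound 3 to compound 4 (beyond the scatter), while the group carried by compound 1 remains well apart, with a number 50 percentage points lower from compound 1 to compound 4 (beyond the scatter). Nothing available accounts for these shifts in terms of mechanism.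

The compounds shown leave open whether the effect of the double bond holds on a longer chain, as only one chain carries both the saturated and the ethenyl form of this group. They also leave open how this assay responds when an amine or a carboxylic acid stands in place of the pyridinyl-bearing group, and whether the order seen at the one tested concentration holds at other concentrations.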